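From 4-hydroxycyclohexyl to isopropyl on the amide nitrogen

A few compounds are considered here, and "the series" means these few. Any claim that something is new, unique, unknown or untested is made for them only; others in the source may bear on it.

In a physicochemical assay for solubility, at pH 6.8 (a lower number here means a less soluble compound, a higher number a more soluble compound), compound 1 `CCNC(=O)c1nc(-c2ccc(CN(C)C)cc2)cnc1N`, which has ethyl on the amide-type nitrogen, gives > 1000000 nM, and this is a limit of the assay, not a number. Compound 2 `CN(C)Cc1ccc(-c2cnc(N)c(C(=O)NC3CCCCC3)n2)cc1`, with cyclohexyl there, gives 190000 nM. Compound 3 `CN(C)Cc1ccc(-c2cnc(N)c(C(=O)NC3CCC(O)CC3)n2)cc1`, with 4-hydroxycyclohexyl there, gives 850000 nM, the higher of the two actual numbers in this assay.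

The compound still unmeasured, compound 4 `CC(C)NC(=O)c1nc(-c2ccc(CN(C)C)cc2)cnc1N`, has isopropyl in place of 4-hydroxycyclohexyl on an amide-type nitrogen. Within the data shown here, three measured steps bear on this change. Putting cyclohexyl in place of ethyl gave an at least 5.2-fold lower number from compound 1 to compound 2 (0.72 log units; beyond the scatter), and hydroxy in place of hydrogen on a saturated ring carbon then gave a 4.5-fold higher number from compound 2 to compound 3 (0.65 log units; beyond the scatter). The direct exchange of ethyl for 4-hydroxycyclohexyl gave an at least 1.1-fold lower number from compound 1 to compound 3 (0.07 log units; that floor lies within the scatter), and that floor lies within the scatter. Isopropyl, like ethyl, has no ring, so compound 4 is expected to stay close to compound 3, given the small floor in an at least 1.1-fold lower number from compound 1 to compound 3 (0.07 log units; that floor lies within the scatter). The expected change is a 1.1-fold lower number from compound 3 to compound 4 (0.05 log units; within the scatter), which is not expected to go beyond the scatter. For compound 4 the estimated value is 750000 nM, with an expected range from 350000 nM to 1000000 nM.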

Compound 4, solubility: > 1000000 nM
Compound 4: only a limit was reported; the forecaster's own chance of this, stated with the estimate: 35%; middle value at least 1.3-fold (0.12 log units) away from the limit.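

In this assay compound 4 gives > 1000000 nM, and this is a limit of the assay, not a number. Isopropyl is thus a second group without a ring, after ethyl, that reaches this limit on the amide-type nitrogen, and the exchange for cyclohexyl gives an at least 5.2-fold higher number from compound 2 to compound 4 (0.72 log units; beyond the scatter), so compound 2 now stands apart from two such compounds rather than one, while the exchange for 4-hydroxycyclohexyl gives an at least 1.1-fold higher number from compound 3 to compound 4 (0.07 log units; that floor lies within the scatter), which does not set compound 4 apart from compound 3. The step between the two compounds at the limit, compound 1 and compound 4, cannot be read, so ethyl and isopropyl cannot be ranked against each other: the limit of > 1000000 nM in this assay, at which 2 of the 4 values shown sit.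

The compounds shown leave open how a longer chain such as butyl, or a small ring such as cyclopropyl, would read on this nitrogen, and so at what size or shape of group the number starts to fall short of the limit. They also leave open whether an amine in place of the hydroxy on the cyclohexyl ring would give a step like a 4.5-fold higher number from compound 2 to compound 3 (0.65 log units; beyond the scatter).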